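Swapping methoxy for dimethylamino in compound 3

The compounds below may be only part of what the source reports. "The series", "measured", "known", "first", "only" and "open" are said of these compounds alone.

Measured in a functional assay on MCF7 cells (Homo sapiens) for antiproliferative activity, read by MTT assay, with a stated time of 48 h; on this read-out lower numbers stand for stronger inhibition and higher numbers for weaker inhibition:
- compound 1 `C=C(c1cc(OC)c(OC)c(OC)c1)c1ccc(OC)cc1NC(=O)CN(C)C`: 390 nM
- compound 2 `C=C(c1cc(OC)c(OC)c(OC)c1)c1ccc(OC)c(O)c1NC(=O)COC`: 560 nM

Compound 2, at 560 nM, cannot be separated from compound 1, at 390 nM, because the two values lie within the usual scatter. Compound 3 `C=C(c1cc(OC)c(OC)c(OC)c1)c1ccc(OC)c(O)c1NC(=O)CN(C)C` has dimethylamino in place of methoxy on a saturated chain carbon bound to a carbonyl carbon. Within the data shown here, no measured pair shows this change alone, so no step beyond the scatter is expected in this assay. The estimated 1.3-fold lower number from compound 2 to compound 3 (0.11 log units; within the scatter) is small. For compound 3, the expected value is 430 nM, within an estimated range of 150 nM to 1200 nM.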

Compound 3, half-maximal inhibitory concentration: 210 nM
Estimate against measurement, compound 3: 2.0-fold (0.31 log units) above; the measured number falls inside the stated range.
By their numbers in this assay, from the lowest: compounds 3, 1 and 2 (each within the scatter of the next, the first and the last beyond it).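

In this assay, among these compounds, dimethylamino in place of methoxy on a saturated chain carbon bound to a carbonyl carbon gives a 2.7-fold lower number from compound 2 to compound 3 (0.43 log units; beyond the scatter), the first step here to clear the scatter. Hydroxy in place of hydrogen on an aromatic carbon gives a 1.9-fold lower number from compound 1 to compound 3 (0.27 log units; within the scatter), so that change cannot be told apart from no change. No supporting measurement accounts for either step. The compounds shown leave open how diethylamino, a primary amine or a carboxylic acid would compare on that same chain carbon. They also leave open whether the methoxy-to-dimethylamino step would hold without the hydroxy.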